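Adding a Methoxy to the Phenyl Ring of Compound 1

A few compounds are considered here, and "the series" means these few. Any claim that something is new, unique, unknown or untested is made for them only; others in the source may bear on it.

Going by the values given here, compound 1 `COc1ccc2[nH]c(-c3ccccc3)c(C3=C(Br)C(=O)NC3=O)c2c1` gives 2.48 in a physicochemical assay for lipophilicity (a lower number here means a more polar compound, a higher number a more lipophilic compound), the lower of the two numbers measured so far. Compound 2 `CCCCCCc1ccc2[nH]c(-c3ccccc3)c(C3=C(Br)C(=O)NC3=O)c2c1` gives 4.39 in this assay, and the change is a number 1.91 log units higher from compound 1 to compound 2 (beyond the scatter). Compound 3 `COc1cccc(-c2[nH]c3ccc(OC)cc3c2C2=C(Br)C(=O)NC2=O)c1` differs from compound 1 by methoxy in place of hydrogen on an aromatic carbon. Among the compounds with values here, the only measured step exchanges methoxy for hexyl, a different change, so it does not bear directly on placing a methoxy where a hydrogen stood. The step for compound 3 is therefore expected to be a number 0.03 log units lower from compound 1 to compound 3 (within the scatter), not beyond the scatter. Compound 3 is estimated at 2.45, with a range from 2.1 to 2.8.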

Compound 3, partition coefficient: 2.79
For compound 3 the middle estimate is 0.34 log units below the measured one; measured number inside the range.
By their numbers in this assay, from the lowest: compound 1; then compound 3; then compound 2.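

In this assay, changing phenyl to 3-methoxyphenyl gives a number 0.31 log units higher from compound 1 to compound 3 (beyond the scatter). Going by these compounds alone, this is the only measured change on this phenyl ring, and it shows that even this small group, with 2 heavy atoms, can shift the number beyond the scatter. Nothing measured here gives a reason for the step. Going by these compounds, whether an amine or a carboxylic acid in the same place would move the number the other way remains open. So does whether a longer chain, such as butoxy, would raise it further.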